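This account rests on a few compounds, and the source may have more. Where it says the series, first, only, none or still open, it means among the compounds named here.

Compound 1, with the structure `CCCCCCCCC#C[C@@H](O)[C@@H](N)CO`, is the only entry in this series with a number: in an assay on CHO cells for inhibition of sphingosine kinase 1 (Homo sapiens), tested at 10 uM (on this read-out higher numbers stand for more inhibition at the one concentration tested (going by the name of the read-out) and lower numbers for less inhibition), compound 1 gives 13.7%. Compound 2, `CCCCC#C[C@@H](O)[C@@H](N)CO`, is reported in this assay as "not active" (no number reported), without a number. Compound 3, `CCCCCCCCCCCCCC#C[C@@H](O)[C@@H](N)CO`, differs from compound 1 by pentyl in place of hydrogen on a saturated chain carbon, eight bonds along the chain from a triple-bonded carbon. For the measured compounds named here, no step between measured compounds is available, so the size of the change is open; a modest increase is expected, though it may stay within the usual scatter. For compound 3 the expected step is a number 11.3 percentage points higher from compound 1 to compound 3 (beyond the scatter), giving an estimate of 25%, within 5% to 50%.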

Compound 3, a percentage reported as inhibition, at one concentration (the size of the read-out at that concentration, not a potency): 24.4%
Compound 3: the middle estimate sits 0.6 percentage points above what was measured, within the range that was stated.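

In this assay, for the compounds shown here, pentyl in place of hydrogen on a saturated chain carbon, eight bonds along the chain from a triple-bonded carbon, gives a number 10.7 percentage points higher from compound 1 to compound 3 (beyond the scatter) and this is the first step that can be read. It shows that this position accepts the added carbons with more inhibition at the one concentration tested, not less. No measurement shown here accounts for the rise. Going by these compounds, whether a still longer chain would raise the number further stays open. So does the effect of an amine or a carboxylic acid at this place.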